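Exchanging one group on compound 1

The compounds below may be only part of what the source reports. "The series", "measured", "known", "first", "only" and "open" are said of these compounds alone.

Compound 1 `O=C1c2ccccc2C(=O)N1CCOC(=S)N(C(=O)c1ccc(C(F)(F)F)cc1)c1ccc(Cl)cc1` gives 10000 nM here
Compound 2 `Cc1ccc(C(=O)N(C(=S)OCCN2C(=O)c3ccccc3C2=O)c2ccc(C)cc2)cc1` gives 83000 nM here

In an ADME assay on MT4 cells (Homo sapiens) for cytotoxicity, read by MTT assay (a higher number here means that more compound is tolerated, a lower number that less compound is tolerated), compound 1 has the lower of the two numbers, and its gap to compound 2 lies beyond the scatter. Compound 3 `O=C1c2ccccc2C(=O)N1CCOC(=S)N(C(=O)c1cccc(Cl)c1Cl)c1ccc(Cl)cc1` carries 2,3-dichlorophenyl in place of 4-(trifluoromethyl)phenyl on a carbonyl carbon (see 2,3-dichlorophenyl in place of 4-(trifluoromethyl)phenyl on a carbonyl carbon for the count). The two measured compounds differ in more than one place, and neither shows this exchange alone. No step beyond the scatter is expected in this assay, and the estimated change is a 1.4-fold higher number from compound 1 to compound 3 (0.15 log units; within the scatter) in size. For compound 3 the expected value is 14000 nM with an estimated range from 4000 nM to 50000 nM around it.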

Compound 3, half-maximal cytotoxic concentration: 54000 nM
Beside the measured number, compound 3's estimate is 3.9-fold (0.59 log units) below it; measured number outside the range, above it.
By their numbers in this assay, from the lowest: compound 1; then compounds 3 and 2 (each within the scatter of the next).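

In this assay, putting 2,3-dichlorophenyl in place of 4-(trifluoromethyl)phenyl on a carbonyl carbon gives a 5.4-fold higher number from compound 1 to compound 3 (0.73 log units; beyond the scatter), the first single exchange seen here. It shows that this one group, with the rest of compound 1 unchanged, can move the number beyond the scatter. Nothing measured here explains the step.

Going by these compounds, it remains open whether the step follows from losing trifluoromethyl or from gaining the two chlorines. A phenyl carrying a single chlorine, or one carrying a methoxy group, could help separate the two.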